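Methyl for methoxy at the weak end of the series

The source may hold more compounds than are shown below. What is called first, only, known or untested is meant among the compounds shown, and "the series" means these compounds.

In a functional assay on HCT-116 cells (Homo sapiens) for inhibition, read by MTT assay, with a stated time of 48 h (a lower number here means a stronger inhibitor, a higher number a weaker inhibitor), compound 1 (`C/C=C/C(=O)N(Cc1ccc(OC)c(OC)c1)c1cc(OC)c(OC)c(OC)c1`) gives 32800 nM and holds the higher of the two measured numbers, which makes it the weaker inhibitor. Compound 2 (`CCC/C=C/C(=O)N(Cc1ccc(OC)c(O)c1)c1cc(OC)c(OC)c(OC)c1`) gives 95 nM, a far lower number and a gap beyond the scatter. Among the measured compounds shown here, these two compounds do not differ in a single place, so no measured step bears directly on the next change.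

Compound 3 (`C/C=C/C(=O)N(Cc1ccc(OC)c(C)c1)c1cc(OC)c(OC)c(OC)c1`) keeps the frame of compound 1 but carries methyl in place of methoxy on an aromatic carbon, ortho to a methoxy group and meta to a large group: methyl in place of methoxy on an aromatic carbon. For the measured compounds named here, with no measured precedent for this swap, the expectation rests on compound 1 alone. The estimated step is a 1.3-fold lower number from compound 1 to compound 3 (0.12 log units; within the scatter), with no change beyond the scatter expected in this assay. Compound 3 is expected at 25000 nM, with an estimated range from 6000 nM to 70000 nM.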

Compound 3, half-maximal inhibitory concentration: 23500 nM
Compound 3: the middle estimate sits 1.1-fold (0.03 log units) above what was measured, and the stated range covers the measured number.
By their numbers in this assay, from the lowest: compound 2; then compounds 3 and 1 (each within the scatter of the next).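

In this assay, methyl in place of methoxy on this aromatic carbon, ortho to a methoxy group and meta to a large group, gives a 1.4-fold lower number from compound 1 to compound 3 (0.14 log units; within the scatter) and so leaves compound 3 within the scatter of compound 1. This first measured step in the series shows that, on the frame of compound 1, the methoxy at this position, with its oxygen and its hydrogen-bond acceptor, can be exchanged for methyl without a shift beyond the scatter. No independent data bear on why this exchange leaves the number in place.

Compound 2 does not differ from compound 1 in a single place, so the value of compound 2 at 95 nM cannot be assigned to any one change. As far as these compounds go, whether an amine, a chlorine atom or a longer chain on this carbon would stay in the same range remains open, as does the effect of methyl here on the frame of compound 2.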